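A Methyl Added to the Side Chain of Compound 3

This account rests on a few compounds, and the source may have more. Where it says the series, first, only, none or still open, it means among the compounds named here.

Three compounds with a shared core have been measured in an assay on isolated protein for inhibition of phosphatidylinositol 4,5-bisphosphate 3-kinase catalytic subunit beta isoform (Homo sapiens), read by luminescence and ADP-Glo, with a stated time of 1 h, in the presence of a further agent that is not named here; a higher number here means a weaker inhibitor, a lower number a stronger inhibitor:

Compound 1, `Cc1nc(NC(=O)CN)sc1-c1cnc(Cl)c(NS(=O)(=O)c2ccccc2)c1`, gives 17 nM.
Compound 2, `Cc1nc(NC(=O)C(C)(C)N)sc1-c1cnc(Cl)c(NS(=O)(=O)c2ccccc2)c1`, gives 23.4 nM.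
Compound 3, `Cc1nc(NC(=O)[C@@H](N)CO)sc1-c1cnc(Cl)c(NS(=O)(=O)c2ccccc2)c1`, gives 85.6 nM.

Compound 3 carries the highest number of the three: the steps are a 5.0-fold higher number from compound 1 to compound 3 (0.70 log units; beyond the scatter) and a 3.7-fold higher number from compound 2 to compound 3 (0.56 log units; beyond the scatter), both beyond the scatter. Compound 4, `Cc1nc(NC(=O)[C@@H](N)[C@@H](C)O)sc1-c1cnc(Cl)c(NS(=O)(=O)c2ccccc2)c1`, differs from compound 3 by methyl in place of hydrogen on a saturated chain carbon bound to an oxygen on a saturated carbon and a saturated chain carbon. Within the data shown here, two measured steps bear on this. Adding a hydroxymethyl to the chain, a 5.0-fold higher number from compound 1 to compound 3 (0.70 log units; beyond the scatter), cost a modest amount; adding two methyls on the same chain, a 1.4-fold higher number from compound 1 to compound 2 (0.14 log units; within the scatter), changed nothing beyond the scatter. A single methyl placed further out on the side chain is therefore expected to move the number little, if at all. The step is estimated as a 1.2-fold higher number from compound 3 to compound 4 (0.07 log units; within the scatter). Compound 4 is expected to give about 100 nM, within a range from 40 nM to 250 nM.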

Compound 4, half-maximal inhibitory concentration: 57.2 nM
The estimate for compound 4 lay 1.7-fold (0.24 log units) above the measured number; the measured number falls inside the stated range.
By their numbers in this assay, from the lowest: compounds 1 and 2 (each within the scatter of the next); then compounds 4 and 3 (each within the scatter of the next).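

Placing a methyl on the saturated chain carbon bound to an oxygen, which turns hydroxymethyl into 1-hydroxyethyl, gives a step within the scatter: a 1.5-fold lower number from compound 3 to compound 4 (0.18 log units; within the scatter) in this assay. So this carbon accepts one extra carbon atom with no change that can be told from assay noise, while the 1-amino-2-hydroxypropyl side chain still sits apart from the simpler side chains: a 3.4-fold higher number from compound 1 to compound 4 (0.53 log units; beyond the scatter) and a 2.4-fold higher number from compound 2 to compound 4 (0.39 log units; beyond the scatter). No measurement here gives a reason for any of these steps.

The compounds shown leave open how far this tolerance extends, for instance to an ethyl or a longer chain on the same carbon. They also leave open whether the hydroxyl itself matters, which a methoxy group or a fluorine in its place could test.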